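The source may report more compounds than this note shows. Statements on the series, on what has been measured and on what is new or still open speak of the compounds shown alone.

Measured in an ADME assay (liver, Mus musculus) for metabolic stability, using microsomes; a lower number here means that the compound disappears faster, a higher number that the compound lasts longer:
Compound 1 `CCc1nc2ccc(Cl)cn2c1C(=O)NCc1ccc(-c2ccc(C)cc2)cc1`: 0.677 h
Compound 2 `CCc1nc2cc(Cl)ccn2c1C(=O)NCc1ccc(-c2ccc(C(=O)O)cc2)cc1`: > 2 h

Compound 2 stands on a limit of the assay and not on a number: the limit of > 2 h in this assay, at which 1 of the 2 values shown sits. Compound 3 `CCc1nc2cc(Cl)ccn2c1C(=O)NCc1ccc(N2CCCCC2)cc1` differs from compound 2 by one swap, piperidin-1-yl in place of 4-carboxyphenyl on an aromatic carbon. Going by the values given here, no measured pair of compounds differs in one place alone, so the evidence is thin. A fall in this assay beyond the scatter is expected, resting on compound 1, which has no 4-carboxyphenyl either and gives 0.677 h. The expected step is an at least 4.0-fold lower number from compound 2 to compound 3 (0.60 log units; beyond the scatter). For compound 3 the estimated half-life is 0.5 h, with an expected range from 0.15 h to 1.5 h.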

Compound 3, half-life: 0.0383 h
Compound 3: the middle estimate sits 13-fold (1.12 log units) above what was measured; the measured number lies below the stated range.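

In this assay, the swap on this aromatic carbon gives an at least 52-fold lower number from compound 2 to compound 3 (1.71 log units; beyond the scatter), so a change in this one place can on its own shift the half-life by a large margin. Going by these compounds alone, this is the first comparison in which only this group differs. The true step could be larger still, because compound 2 rests on a limit and not on a number: the limit of > 2 h in this assay, at which 1 of the 3 values shown sits.

Still open, going by these compounds, is whether a plain phenyl, without the carboxylic acid, would behave more like 4-carboxyphenyl or like piperidin-1-yl. On these data alone, a morpholine ring in place of piperidin-1-yl is equally open.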